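This account rests on a few compounds, and the source may have more. Where it says the series, first, only, none or still open, it means among the compounds named here.

Measured in an ADME assay on HUVEC cells (Homo sapiens) for antiproliferative activity, read by MTT assay, with a stated time of 48 h; on this read-out lower numbers stand for stronger inhibition and higher numbers for weaker inhibition:
Compound 1 `COc1ccc(-n2nncc2CN2C(=O)C3(C(C#N)=C(N)Oc4c(N)cc5nc6ccccc6nc5c43)c3ccccc32)cc1`: > 50000 nM
Compound 2 `COc1ccccc1-n1nncc1CN1C(=O)C2(C(C#N)=C(N)Oc3c(N)cc4nc5ccccc5nc4c32)c2ccccc21`: > 50000 nM

The value for compound 1 is a limit of the assay rather than a number. The value for compound 2 is likewise only a limit. Compound 2 therefore stands nowhere definite on the numbers shown. Among the compounds with values here, the one measured step, a step that the two limits leave unreadable from compound 1 to compound 2, is accordingly unreadable; the only evidence on it is the limit of > 50000 nM in this assay, at which 2 of the 2 values shown sit.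

Compound 3 `Cc1ccc(C)c(-n2nncc2CN2C(=O)C3(C(C#N)=C(N)Oc4c(N)cc5nc6ccccc6nc5c43)c3ccccc32)c1` differs from compound 2 in that (2,5-dimethylphenyl in place of 2-methoxyphenyl on an aromatic nitrogen). Within the data shown here, no measured step speaks to this change, and the single comparison available gives neither size nor direction. Compound 3 is therefore expected to behave as compound 2 did, most likely again returning only a limit in this assay. The step that the limit leaves unreadable from compound 2 to compound 3 that this estimate implies is expected to be none beyond the scatter. The estimate for compound 3 is 60000 nM, within 20000 nM to 200000 nM.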

Compound 3, half-maximal inhibitory concentration: > 50000 nM
Compound 3 gave a limit, no number (the forecaster's own chance of this, stated with the estimate: 85%); the middle value does not contradict the limit.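

In this assay compound 3 returns only a limit, as compound 1 and compound 2 did, so no step among these three compounds can be read: the limit of > 50000 nM in this assay, at which 3 of the 3 values shown sit.

The compounds shown leave open how far the three actually differ, and whether any change to the shared core would give a number rather than a limit.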